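Cyano-Bearing Analogue With a Straight-Chain Acrylamide Tail

This account rests on a few compounds, and the source may have more. Where it says the series, first, only, none or still open, it means among the compounds named here.

Compound 1 `COc1cc(N(C)CCN(C)C)c(NC(=O)/C=C\C(C)C)cc1Nc1nccc(-c2cn(C)c3ccccc23)n1` gives 4390 nM in a functional assay on HepG2 cells (Homo sapiens) for antiproliferative activity, read by MTT assay, with a stated time of 72 h; a higher number here means a weaker inhibitor, a lower number a stronger inhibitor. Compound 2 `CCC/C=C\C(=O)Nc1cc(Nc2nccc(-c3cn(C)c4ccccc34)n2)c(OC)cc1N(C)CCN(C)C` gives 431 nM in this assay. Compound 3 `COc1cc(N(C)CCN(C)C)c(NC(=O)/C=C\C(C)C)cc1Nc1ncc(C#N)c(-c2cn(C)c3ccccc23)n1` gives 1810 nM in this assay.

Compound 4 `CCC/C=C\C(=O)Nc1cc(Nc2ncc(C#N)c(-c3cn(C)c4ccccc34)n2)c(OC)cc1N(C)CCN(C)C` has not yet been measured. It differs from compound 3 by propyl in place of isopropyl on a double-bonded chain carbon bound to a double-bonded chain carbon. The same change has been made once before among these compounds, from compound 1 to compound 2: propyl in place of isopropyl on a double-bonded chain carbon bound to a double-bonded chain carbon. That step made a 10-fold lower number from compound 1 to compound 2 (1.01 log units; beyond the scatter). The place of the change reads the same in both pairs, so it is the same change, made on two different cores. The two cores differ in that compound 3 carries cyano in place of hydrogen on an aromatic carbon, and that change on its own gave a 2.4-fold lower number from compound 1 to compound 3 (0.38 log units; beyond the scatter). Compound 3 therefore stands between compound 1 and compound 2.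

Among the compounds with values here, whether the large step seen from compound 1 to compound 2 carries over to the cyano-bearing core cannot be checked from anything measured here; only one example of the change exists. Compound 4 is expected to show an 8.2-fold lower number from compound 3 to compound 4 (0.92 log units; beyond the scatter), a step estimated to be of roughly the same kind and size as the earlier one because a 10-fold lower number from compound 1 to compound 2 (1.01 log units; beyond the scatter) was well beyond the scatter. On that basis compound 4 is estimated at 220 nM in this assay, with the likely range set between 80 nM and 700 nM.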

Compound 4, half-maximal inhibitory concentration: 1690 nM
Beside the measured number, compound 4's estimate is 7.7-fold (0.89 log units) below it, and the stated range ends below it.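

In this assay, putting propyl in place of isopropyl on the cyano-bearing core gives a 1.1-fold lower number from compound 3 to compound 4 (0.03 log units; within the scatter), so the large step seen on the core of compound 1 does not reappear here, and the two steps differ: the same change on two cores in this assay, a 10-fold lower number (1.01 log units; beyond the scatter) from compound 1 to compound 2 and a 1.1-fold lower number (0.03 log units; within the scatter) from compound 3 to compound 4, 9.5-fold (0.98 log units) apart, beyond the scatter of two such steps. Read the other way, cyano in place of hydrogen on an aromatic carbon gives a 3.9-fold higher number from compound 2 to compound 4 (0.59 log units; beyond the scatter) in the propyl pair, a step in the opposite direction from the one in the isopropyl pair: the same change on two cores in this assay, a 2.4-fold lower number (0.38 log units; beyond the scatter) from compound 1 to compound 3 and a 3.9-fold higher number (0.59 log units; beyond the scatter) from compound 2 to compound 4, 9.5-fold (0.98 log units) apart, beyond the scatter of two such steps. This shows that in these compounds the effect of the change from isopropyl to propyl depends on the core that carries it and cannot simply be carried from one core to the other, but it rests on a single set of four compounds and does not show why the two cores respond differently or how the change would behave on any further core.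

The compounds shown leave open whether a longer chain such as pentyl, or a cyclopropyl group, at that place on the chain would follow propyl or isopropyl on each core. They also leave open whether a chlorine or a trifluoromethyl group in place of the cyano would give the same pattern.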